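The source may hold more compounds than are shown below. What is called first, only, known or untested is meant among the compounds shown, and "the series" means these compounds.

Notes on the sulfur substituent in an ADME assay on MOLT-3 cells (Homo sapiens) for cytotoxicity, with a stated time of 7 days; a lower number here means that less compound is tolerated, a higher number that more compound is tolerated. Compound 1 (`CSc1nc(N)nc2c1ncn2/C=C1/CC1(CO)CO`) gives > 20000 nM as a limit of the assay, not a number. Compound 2 (`CCCCSc1nc(N)nc2c1ncn2/C=C1/CC1(CO)CO`) gives > 20000 nM as a limit too, so its position is known only as a limit. What the series shows so far is the limit of > 20000 nM in this assay, at which 2 of the 2 values shown sit, and no more.

Compound 3 (`Nc1nc(SCc2ccccc2)c2ncn(/C=C3/CC3(CO)CO)c2n1`) carries phenyl in place of propyl on a saturated chain carbon bound to a sulfur, which reads as butylsulfanyl to benzylsulfanyl. Among the measured compounds shown here, the one measured step bearing on this is a step that the two limits leave unreadable from compound 1 to compound 2 and it offers no size to carry over. No step beyond the scatter is therefore expected in this assay, and no direction can be assigned with confidence. The expected step is a number no higher from compound 2 to compound 3 (the limit leaves the size open) on this reading. For compound 3 the estimated value is 20000 nM within a range of 8000 nM to 25000 nM and a report as a limit again is likely.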

Compound 3, half-maximal cytotoxic concentration: > 20000 nM
Compound 3 was reported as a limit (the forecaster's own chance of this, stated with the estimate: 70%); the middle value lies on the limit itself.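

In this assay, compound 1, compound 2 and compound 3 all stand as limits of the assay, so no step among them can be read: the limit of > 20000 nM in this assay, at which 3 of the 3 values shown sit.

The compounds shown leave open whether any sulfur substituent gives a readable value, and how the butylsulfanyl and benzylsulfanyl groups compare.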